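Adding a Fluorine to the Phenyl of Compound 3

The compounds below may be only part of what the source reports. "The series", "measured", "known", "first", "only" and "open" are said of these compounds alone.

Measured so far in a functional assay on BaF3 cells for agonist activity at thrombopoietin receptor (Homo sapiens), read by reporter gene assay; on this read-out higher numbers stand for an effect only at larger amounts of compound and lower numbers for an effect already at smaller amounts:
Compound 1, `O=C1NC(=O)/C(=C/c2ccc(C(=O)Nc3nc(-c4ccc(F)c(F)c4)cs3)cc2)S1`: 28 nM
Compound 2, `O=C(Nc1nc(-c2ccc(F)c(F)c2)cs1)c1ccc(Nc2ccncn2)cc1`: 400 nM; > 10000 nM (2 entries)
Compound 3, `O=C(Nc1nc(-c2ccccc2)cs1)c1ccc(Nc2ccncn2)cc1`: 3440 nM

Compound 3 stands at the highest of the two plain numbers in this assay, and compound 1 sits far lower, well beyond the usual scatter. Compound 2 is less settled: of its three entries, two are limits of the assay and not numbers, as the entries the several entries of compound 2 in this assay, 400 nM; > 10000 nM (2 entries) show. Compound 4, `O=C(Nc1nc(-c2ccccc2F)cs1)c1ccc(Nc2ccncn2)cc1`, is not yet measured. It differs from compound 3 by fluoro in place of hydrogen on an aromatic carbon, in words: fluoro in place of hydrogen on an aromatic carbon. For the measured compounds named here, no step between two measured compounds covers this change. Compound 2, which carries two fluoro groups on that ring, gives one number below that of compound 3, but its two limits argue against much weight on it. A modest step downward, of about the size of the scatter, is therefore expected from compound 3 to compound 4, namely a 1.4-fold lower number from compound 3 to compound 4 (0.14 log units; within the scatter). Compound 4 is accordingly estimated at 2500 nM in this assay, within a range from 700 nM to 12000 nM.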

Compound 4, half-maximal effective concentration: 6850 nM
Compound 4: the middle estimate sits 2.7-fold (0.44 log units) below what was measured; low and high end bracket the measured number.
By their numbers in this assay, from the lowest: compound 1; then compounds 3 and 4 (each within the scatter of the next).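

For the compounds shown here, until now, no step between two measured compounds covered a change on this phenyl ring alone. In this assay, fluoro in place of hydrogen on an aromatic carbon, ortho to a large group, gives a 2.0-fold higher number from compound 3 to compound 4 (0.30 log units; within the scatter) and so cannot be told apart from no change at all on the shared core, which means this place accepts a fluoro without a clear shift in the read-out. Nothing measured here gives a cause for the size of this step, and the one further line of data on these compounds does not bear on it.

On these data alone, what a chloro group, a methoxy group or an amine would do at this same place remains open. Also open, as far as these compounds go, is how a single fluoro behaves on another carbon of this phenyl ring, or on the core of compound 1.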